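The source may hold more compounds than are shown below. What is called first, only, known or untested is meant among the compounds shown, and "the series" means these compounds.

In a physicochemical assay for solubility, in phosphate buffer, with a stated time of 24 h, at pH 7.4 (on this read-out higher numbers stand for higher solubility and lower numbers for lower solubility), compound 3 `COc1ccc(-c2ccc(OCc3cc(C(=O)NS(=O)(=O)c4c(C)noc4C)oc3C)cc2)c(C)c1` gives 200 ug/mL, the higher of the two actual numbers. Compound 1 `COc1ccc(-c2ccc(OCc3cc(C(=O)NS(=O)(=O)c4ccccc4)oc3C)cc2)c(C)c1` gives 20 ug/mL. Compound 2 `COc1ccc(-c2ccc(OCc3cc(C(=O)NS(=O)(=O)c4ccc(CN)cc4)oc3C)cc2)cc1` gives only a limit of the assay, < 0.6 ug/mL. For the measured compounds named here, the one measured step, a 10-fold higher number from compound 1 to compound 3 (1.00 log units; beyond the scatter), puts 3,5-dimethyl-1,2-oxazol-4-yl in place of phenyl on a sulfonyl sulfur. Compound 4 `COc1ccc(-c2ccc(OCc3cc(C(=O)NS(=O)(=O)c4c(C)noc4C)oc3C)cc2)nc1` differs from compound 3 elsewhere: 5-methoxypyridin-2-yl in place of 4-methoxy-2-methylphenyl on an aromatic carbon, with 5-methoxypyridin-2-yl in place of 4-methoxy-2-methylphenyl on an aromatic carbon. Going by the values given here, no measured step covers this place, so the step at the sulfonyl sulfur gives no direct guide to its size. The expected change in this assay is a 1.3-fold lower number from compound 3 to compound 4 (0.12 log units; within the scatter), which is none beyond the scatter. For compound 4 the estimate is 150 ug/mL, with an expected range from 30 ug/mL to 600 ug/mL.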

Compound 4, solubility: 90 ug/mL
For compound 4 the middle estimate is 1.7-fold (0.22 log units) above the measured one; the range from low to high includes it.
By their numbers in this assay, from the lowest: compound 1; then compound 4; then compound 3. At a limit, below all of these: compound 2.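

In this assay, putting 5-methoxypyridin-2-yl in place of 4-methoxy-2-methylphenyl gives a 2.2-fold lower number from compound 3 to compound 4 (0.35 log units; beyond the scatter). For the compounds shown here, this is the first reading of a change away from the sulfonyl sulfur, and it shows that this position, on an aromatic carbon para to a large group, moves the number beyond the scatter. No measurement shown gives a cause for this step.

The compounds shown leave open how much of the step belongs to the ring nitrogen and how much to the methyl group that leaves. They also leave open whether an amine or a carboxylic acid here would shift the number further.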